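Methylating the ring hydroxyl on two related cores

A few compounds are considered here, and "the series" means these few. Any claim that something is new, unique, unknown or untested is made for them only; others in the source may bear on it.

Compound 1 `COc1ccc(O)c2c(O)ccnc12` and compound 2 `COc1ccc(OC)c2c(O)ccnc12` share one core. Compound 3 `COc1cc2c(c(O)c1OC)c(=O)ccn2C` and compound 4 `COc1cc2c(c(OC)c1OC)c(=O)ccn2C` share another. The difference between the two cores is not broken down here.

In a functional assay on HL-60 cells (Homo sapiens) for antiproliferative activity (on this read-out lower numbers stand for stronger inhibition and higher numbers for weaker inhibition), compound 1 gives 17700 nM. For compound 2 the assay reports only a limit, > 30000 nM. The change from compound 1 to compound 2 is methyl in place of hydrogen on an oxygen on an aromatic ring, and the step it made in this assay is an at least 1.6-fold higher number from compound 1 to compound 2 (0.22 log units; that floor lies within the scatter). That step is known only as a floor, since it rests on (the limit of > 30000 nM in this assay, at which 2 of the 3 values shown sit).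

For compound 3 the assay likewise reports only a limit, > 30000 nM. The change from compound 3 to compound 4 is methyl in place of hydrogen on an oxygen on an aromatic ring, the same change, at the same place: on an oxygen on an aromatic ring whose other neighbours are aromatic carbon. Within the data shown here, the one measured instance of this change gave no lower number, and compound 3 already sits at the limit.

On that basis the step expected from compound 3 to compound 4 in this assay is a step that the limit leaves unreadable from compound 3 to compound 4, with compound 4 expected to remain at or beyond the limit. Compound 4 is estimated at 60000 nM, within an expected range from 25000 nM to 200000 nM, and a further limit rather than a number is the most likely outcome for compound 4.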

Compound 4, half-maximal inhibitory concentration: > 30000 nM
Compound 4: no number, only a limit; the forecaster's own chance of this, stated with the estimate: 85%; the middle value does not contradict the limit.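

In this assay compound 4 gives > 30000 nM, a limit and not a number. Among these compounds, compound 3 likewise gives only a limit, so no step from compound 3 to compound 4 can be read: the limit of > 30000 nM in this assay, at which 3 of the 4 values shown sit. Left open is whether hydroxy to methoxy shifts the read-out at all on the core of compound 3, where neither compound gives a number.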